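Methylsulfonyl replacing ethyl: expected whole-organism dose

This account rests on a few compounds, and the source may have more. Where it says the series, first, only, none or still open, it means among the compounds named here.

The series is followed in a functional assay on the whole organism (strain Sprague-Dawley) for inhibition, with Rattus norvegicus as the target; a higher number here means that more compound is needed for the effect, a lower number that less compound is needed. Going by the values given here, compound 2 `CCc1cccc2c(=O)c(-c3nn[nH]n3)c[nH]c12` gives 0.312 mg/kg in this assay, the only number among the three values in hand. Compound 1 `O=c1c(-c2nn[nH]n2)c[nH]c2c(Cl)c(Cl)ccc12` reaches only a limit in this assay, > 0.156 mg/kg, and the limit of > 0.156 mg/kg in this assay, at which 1 of the 3 values shown sits, marks where that value sits. Compound 3 `Cc1cccc2cc(C(=O)O)cnc12` likewise reaches only a limit in this assay, > 50 mg/kg, with the limit of > 50 mg/kg in this assay, at which 1 of the 3 values shown sits, marking where its value sits. Among the compounds with values here, no two measured compounds differ in a single place, so no measured step is available as a guide.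

Compound 4 `CS(=O)(=O)c1cccc2c(=O)c(-c3nn[nH]n3)c[nH]c12` has not yet been measured. It differs from compound 2 by methylsulfonyl in place of ethyl on an aromatic carbon. The ethyl, a chain of two carbon atoms, leaves; a methylsulfonyl carrying two hydrogen-bond acceptors enters on an aromatic carbon of a six-membered aromatic ring of carbon only, part of a fused system of two rings.

Within the data shown here, with no measured step to lean on, the step of a 2.2-fold higher number from compound 2 to compound 4 (0.35 log units; beyond the scatter) is expected to run toward more compound being needed, by an amount only somewhat beyond the scatter. Compound 4 is accordingly expected to require 0.7 mg/kg in this assay, with a range from 0.15 mg/kg to 5 mg/kg.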

Compound 4, minimum effective dose: 10 mg/kg
The estimate for compound 4 lay 14-fold (1.15 log units) below the measured number, and the stated range ends below it.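

In this assay, going by these compounds alone, methylsulfonyl in place of ethyl on this aromatic carbon, ortho to a fused ring, gives a 32-fold higher number from compound 2 to compound 4 (1.51 log units; beyond the scatter) and so provides the first single-place comparison. The shared core therefore does not fix the whole-organism dose on its own: the group on this carbon can move the number by a large step, and compound 4 keeps that core yet needs 10 mg/kg in this measurement. The data in hand hold no measured property that bears on the size of this step, and the two limits in the series do not speak to it.

Within the data shown here, only two groups are compared at this carbon, so it remains open whether the dose depends on the size of the group, on its hydrogen-bond acceptors or on something else, and whether ethyl is close to the best choice here. A methoxy, an amine or a longer chain such as propyl on the same carbon would help separate these possibilities and show how the dose changes across a wider range of groups at this position.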